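Methylating the Amide Nitrogen of Compound 3

The source may report more compounds than this note shows. Statements on the series, on what has been measured and on what is new or still open speak of the compounds shown alone.

Of the compounds shown here, three sharing one core have been measured in an assay on microsomes from liver for inhibition of 3-hydroxy-3-methylglutaryl-coenzyme A reductase (Rattus norvegicus); on this read-out higher numbers stand for weaker inhibition and lower numbers for stronger inhibition. Compound 1 `Cc1cccc(CNC(=O)c2nn(-c3ccc(F)cc3)c(OC[C@@H](O)C[C@@H](O)CC(=O)O)c2C(C)C)c1` gives 4.9 nM. Compound 2 `CC(C)c1c(C(=O)N2CCCCC2)nn(-c2ccc(F)cc2)c1OC[C@@H](O)C[C@@H](O)CC(=O)O`, in which the carbonyl carries a piperidin-1-yl group rather than a (3-methylbenzyl)amino group, gives 47 nM. Compound 3 `CC(C)c1c(C(=O)NCc2cccc(Cl)c2)nn(-c2ccc(F)cc2)c1OC[C@@H](O)C[C@@H](O)CC(=O)O` is the chloro counterpart of compound 1, and compound 3 gives 5.4 nM. Among these three numbers compound 3 stands second highest: its nearest neighbour is compound 1 (a 1.1-fold higher number from compound 1 to compound 3 (0.04 log units; within the scatter)), while the only step that stands out is an 8.7-fold lower number from compound 2 to compound 3 (0.94 log units; beyond the scatter).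

Compound 4 `CC(C)c1c(C(=O)N(C)Cc2cccc(Cl)c2)nn(-c2ccc(F)cc2)c1OC[C@@H](O)C[C@@H](O)CC(=O)O` is not yet measured. It differs from compound 3 by methyl in place of hydrogen on an amide-type nitrogen, so the amide hydrogen is gone. Within the data shown here, no measured pair shows exactly this exchange. The closest guides are the two steps in which the amide bearing a hydrogen is swapped for a piperidin-1-yl amide that has none: a 9.6-fold higher number from compound 1 to compound 2 (0.98 log units; beyond the scatter) and an 8.7-fold lower number from compound 2 to compound 3 (0.94 log units; beyond the scatter). Both point the same way, toward weaker inhibition once the hydrogen on the nitrogen is replaced, although the piperidine change also removes the benzyl group, so the methyl alone may cost less. For compound 4 a step of a 3.7-fold higher number from compound 3 to compound 4 (0.57 log units; beyond the scatter) is therefore expected. The estimate for compound 4 in this assay is 20 nM, with a likely range from 6 nM to 70 nM.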

Compound 4, half-maximal inhibitory concentration: 8.3 nM
Compound 4: the middle estimate sits 2.4-fold (0.38 log units) above what was measured; the range from low to high includes it.
By their numbers in this assay, from the lowest: compounds 1, 3 and 4 (each within the scatter of the next); then compound 2.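

In this assay, the step of a 1.5-fold higher number from compound 3 to compound 4 (0.19 log units; within the scatter) stays within the scatter, so on this amide-type nitrogen a methyl can take the place of the amide hydrogen without a change that can be told from repeat-measurement noise, and the amide hydrogen is not required for inhibition at this level in this pair. The gap to the piperidine amide remains with the hydrogen gone from both partners: there is a 5.7-fold lower number from compound 2 to compound 4 (0.75 log units; beyond the scatter), beyond the scatter, while a 1.7-fold higher number from compound 1 to compound 4 (0.23 log units; within the scatter) is within it, so the weaker inhibition of compound 2 goes with the piperidin-1-yl group in place of the (3-chlorobenzyl)(methyl)amino group, and not with the missing hydrogen alone. Nothing available explains why the methyl is tolerated here.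

On these data alone, whether this nitrogen also accepts something larger than methyl, such as an ethyl group or a longer chain ending in a hydroxyl group, remains open. Also open, as far as these compounds go, is whether a simple open-chain amine such as dimethylamino on the carbonyl would behave like piperidin-1-yl, which would show how much of the gap depends on the benzyl group.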